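Phenyl in place of isopropyl: compound 3

The source may report more compounds than this note shows. Statements on the series, on what has been measured and on what is new or still open speak of the compounds shown alone.

Of the compounds shown here, two carry numbers so far. Compound 1 `CC(=O)Oc1ccc(C(=O)Nc2cc3ccc(OCC4CCCNC4)c(C)c3oc2=O)cc1CC=C(C)C` gives 820 nM in a functional assay on MCF7 cells (Homo sapiens) for antiproliferative activity; on this read-out higher numbers stand for weaker inhibition and lower numbers for stronger inhibition. Compound 2 `CC(C)=CCc1cc(C(=O)Nc2cc3ccc(OCCCNCC(C)C)c(C)c3oc2=O)ccc1O` gives 1320 nM in this assay; this is the higher of the two numbers, yet the gap to compound 1 lies within the scatter. Compound 3 `CC(C)=CCc1cc(C(=O)Nc2cc3ccc(OCCCNCc4ccccc4)c(C)c3oc2=O)ccc1O` is not yet measured and differs from compound 2 by phenyl in place of isopropyl on a saturated chain carbon bound to an amine nitrogen. Going by the values given here, no measured pair shows this change, so the step is expected to stay within the scatter in this assay, with no direction favored: a 1.3-fold lower number from compound 2 to compound 3 (0.12 log units; within the scatter) is the expected step. Compound 3 is estimated at 1000 nM, between 400 nM and 2500 nM.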

Compound 3, half-maximal inhibitory concentration: 910 nM
For compound 3 the middle estimate is 1.1-fold (0.04 log units) above the measured one; low and high end bracket the measured number.
By their numbers in this assay, from the lowest: compounds 1, 3 and 2 (each within the scatter of the next).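

In this assay, the series now has its first pair differing in one place: phenyl in place of isopropyl on a saturated chain carbon bound to an amine nitrogen gives a 1.5-fold lower number from compound 2 to compound 3 (0.16 log units; within the scatter) and stays within the scatter. At this place, then, an aromatic ring of carbon only and a branched alkyl group cannot be told apart on this read-out. Nothing available explains this outcome.

Open, as far as these compounds go, is whether a pyridyl or cyclohexyl group at the same place would give a step beyond the scatter. Also open, from the compounds shown here alone, is whether a carboxylic acid or a longer chain there would do so.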